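The compounds below may be only part of what the source reports. "The series", "measured", "known", "first", "only" and "open" are said of these compounds alone.

Measured compounds:
Compound 1, `O=C1NC(O)(CCn2cc(C3=CCCCC3)nn2)C(OCc2ccccc2)=C1OCc1ccccc1`: > 100000 nM
Compound 2, `O=C1NC(O)(CCn2cc(-c3ccccc3)nn2)C(OCc2ccccc2)=C1OCc1ccccc1`: 20500 nM

In a functional assay on MCF7 cells (Homo sapiens) for antiproliferative activity, read by MTT assay, with a stated time of 24 h (a lower number here means a stronger inhibitor, a higher number a weaker inhibitor), compound 1 returns only > 100000 nM, which is a limit of the assay and not a number. In this assay, among the compounds with values here, compound 2 gives 20500 nM, the only number in the set. Compound 2 can therefore be placed against nothing but the result for compound 1. Within the data shown here, the single measured step, an at least 4.8-fold lower number from compound 1 to compound 2 (0.68 log units; beyond the scatter), exchanges the whole pendant ring; it is known only as a floor since compound 1 sits at the limit of > 100000 nM in this assay, at which 1 of the 2 values shown sits.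

Compound 3, `CC(C)(C)c1ccc(-c2cn(CCC3(O)NC(=O)C(OCc4ccccc4)=C3OCc3ccccc3)nn2)cc1`, carries tert-butyl in place of hydrogen on an aromatic carbon. This substitutes on the pendant ring rather than replacing it, so the measured step is only an indirect guide, and no shift beyond the scatter is expected from compound 2. The expected step is a 1.4-fold lower number from compound 2 to compound 3 (0.14 log units; within the scatter). For compound 3 the estimate is 15000 nM, with a range of 5000 nM to 50000 nM.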

Compound 3, half-maximal inhibitory concentration: 25100 nM
Compound 3: the middle estimate sits 1.7-fold (0.22 log units) below what was measured, within the range that was stated.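

Working notes on the pendant ring: in this assay, adding tert-butyl to the phenyl ring, para to a large group, gives a 1.2-fold higher number from compound 2 to compound 3 (0.09 log units; within the scatter), so this position accepts four extra heavy atoms with no shift beyond the scatter. With the substituted ring, the replacement of cyclohex-1-en-1-yl still gives an at least 3.9-fold lower number from compound 1 to compound 3 (0.60 log units; beyond the scatter), so the separation from compound 1 holds for both phenyl-bearing compounds. That step is only a floor, since compound 1 stands at a limit of the assay and not a number: the limit of > 100000 nM in this assay, at which 1 of the 3 values shown sits.

Still open, going by these compounds, is whether an amine or a carboxylic acid at this same place would move the number beyond the scatter, in either direction. A single substituent also says nothing about other positions on the phenyl ring or about the shared core.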